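Ureido in Place of Thiazolylamino: Expected Cytotoxicity

This account rests on a few compounds, and the source may have more. Where it says the series, first, only, none or still open, it means among the compounds named here.

Three compounds share one core and differ at a single aromatic carbon. Compound 1 `N#Cc1c(O)nc(SCc2nc3ccccc3[nH]2)nc1-c1ccccc1` carries a hydroxy there, and in a functional assay on GOTO cells (Homo sapiens) for cytotoxicity, read by MTT assay, with a stated time of 3 days (on this read-out lower numbers stand for stronger inhibition and higher numbers for weaker inhibition), compound 1 gives 7.81 nM. Compound 2 `CNc1nc(SCc2nc3ccccc3[nH]2)nc(-c2ccccc2)c1C#N` has methylamino in its place; compound 2 gives 3.28 nM, which is a 2.4-fold lower number from compound 1 to compound 2 (0.38 log units; beyond the scatter). Compound 3 `N#Cc1c(Nc2nccs2)nc(SCc2nc3ccccc3[nH]2)nc1-c1ccccc1` carries (1,3-thiazol-2-yl)amino and gives 5.1 nM. On these numbers compound 3 sits second highest of the three, but a 1.5-fold lower number from compound 1 to compound 3 (0.19 log units; within the scatter) and a 1.6-fold higher number from compound 2 to compound 3 (0.19 log units; within the scatter), so the three values cannot be separated with confidence.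

Compound 4 `N#Cc1c(NC(N)=O)nc(SCc2nc3ccccc3[nH]2)nc1-c1ccccc1` differs from compound 3 by carbamoyl in place of 1,3-thiazol-2-yl on a nitrogen on an aromatic ring. For the measured compounds named here, the steps that bear on this position are the one between compound 2 and compound 3, where exchanging the group on that nitrogen moved the number only within scatter, and the one between compound 1 and compound 3, also within scatter. Since the exchanges at this position have given at most a modest step, compound 4 is expected to give 5.5 nM, within 2.5 nM to 12 nM. That estimate amounts to an expected 1.1-fold higher number from compound 3 to compound 4 (0.03 log units; within the scatter).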

Compound 4, half-maximal inhibitory concentration: 11.3 nM
The estimate for compound 4 lay 2.1-fold (0.31 log units) below the measured number; the measured number falls inside the stated range.
By their numbers in this assay, from the lowest: compounds 2, 3, 1 and 4 (each within the scatter of the next, the first and the last beyond it).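

In this assay, for the compounds shown here, the carbamoyl group is the first exchange on this nitrogen to give a step beyond the scatter against 1,3-thiazol-2-yl (a 2.2-fold higher number from compound 3 to compound 4 (0.35 log units; beyond the scatter)), where the step from methyl to 1,3-thiazol-2-yl had stayed within it. Against methyl the step is also beyond the scatter, though still modest (a 3.4-fold higher number from compound 2 to compound 4 (0.54 log units; beyond the scatter)), so the group on this nitrogen can shift the number after all. Against hydroxy on the aromatic carbon, ureido stays within the scatter (a 1.4-fold higher number from compound 1 to compound 4 (0.16 log units; within the scatter)), so these two groups cannot be told apart on this read-out.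

The compounds shown leave open whether the higher number goes with the carbonyl of the carbamoyl group or with the loss of the ring. An unsubstituted amine, an acetyl group or a longer chain on this nitrogen would help separate the two. Nothing given here accounts for the step.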